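Methoxycarbonyl to Benzyloxycarbonyl: One Step Awaiting Its Number

A few compounds are considered here, and "the series" means these few. Any claim that something is new, unique, unknown or untested is made for them only; others in the source may bear on it.

Compound 1 `C=C1[C@H](O)[C@]23C[C@@]1(O)CC[C@H]2[C@@]12C=C[C@H](O)[C@](C)(C(=O)O1)[C@H]2[C@@H]3C(=O)OCc1ccccc1` gives > 100 ug/mL as a limit
Compound 2 `C=C1C(=O)[C@]23C[C@@]1(Cl)CC[C@H]2[C@@]12C=CC(=O)[C@](C)(C(=O)O1)[C@H]2[C@@H]3C(=O)OC` gives 6.5 ug/mL as a number

Within the data shown here, in a functional assay on HL-60 cells (Homo sapiens) for cytotoxicity, read by MTT assay (on this read-out lower numbers stand for stronger inhibition and higher numbers for weaker inhibition), compound 2 stands at 6.5 ug/mL as the only true number so far. Compound 3 `C=C1C(=O)[C@]23C[C@@]1(Cl)CC[C@H]2[C@@]12C=CC(=O)[C@](C)(C(=O)O1)[C@H]2[C@@H]3C(=O)OCc1ccccc1` differs from compound 2 by phenyl in place of hydrogen on a saturated chain carbon bound to an oxygen next to a carbonyl group in one place: phenyl in place of hydrogen on a saturated chain carbon bound to an oxygen next to a carbonyl group. Among the measured compounds shown here, no measured step covers this change, so no shift beyond the scatter is expected in this assay in either direction. The expected step is a 1.1-fold lower number from compound 2 to compound 3 (0.03 log units; within the scatter) and stays within that scatter. For compound 3 the estimated value is 6 ug/mL with an expected range from 2 ug/mL to 20 ug/mL for the coming measurement.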

Compound 3, half-maximal inhibitory concentration: 2.7 ug/mL
Compound 3: the middle estimate sits 2.2-fold (0.35 log units) above what was measured; the measured number falls inside the stated range.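

In this assay, among these compounds, the change from methoxycarbonyl to benzyloxycarbonyl gives a 2.4-fold lower number from compound 2 to compound 3 (0.38 log units; beyond the scatter), the first step that can be read at this position. It shows that phenyl in place of hydrogen here is tolerated and comes with a modest shift towards stronger inhibition, beyond the scatter. Nothing measured here accounts for this step.

The compounds shown leave open whether the aromatic ring itself matters, since a cyclohexyl ring or a longer alkyl chain could give a similar number. From the compounds shown here alone, how a carboxylic acid at this place would read also remains open.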